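Swapping the ring on the nitrogen of compound 2

The compounds below may be only part of what the source reports. "The series", "measured", "known", "first", "only" and "open" are said of these compounds alone.

Measured compounds:
compound 1 `COc1ccc(C2=NN(C3=NC(c4ccccc4)CS3)C(c3cccc4ccccc34)C2)cc1` – 3310 nM
compound 2 `O=C1CSC(N2N=C(c3ccc(Cl)cc3)CC2c2cccc3ccccc23)=N1` – 8840 nM
compound 3 `O=C1CSC(N2N=C(c3ccc(F)cc3)CC2c2cccc3ccccc23)=N1` – 11300 nM

All three share one core, and all were tested in a functional assay on HeLa cells (Homo sapiens) for inhibition, read by CCK-8 assay, with a stated time of 48 h; a lower number here means a stronger inhibitor, a higher number a weaker inhibitor. On these numbers compound 2 stands second highest of three; its nearest neighbour is compound 3, which differs only by a fluoro in place of chloro on an aromatic carbon and shows a 1.3-fold higher number from compound 2 to compound 3 (0.11 log units; within the scatter). Its furthest neighbour is compound 1, whose number is lower by a margin beyond the scatter.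

Compound 4 `Clc1ccc(C2=NN(C3=NC(c4ccccc4)CS3)C(c3cccc4ccccc34)C2)cc1` is built from compound 2 by one change: a group of 11 heavy atoms (9 carbon, 1 nitrogen, 1 sulfur; one five-membered non-aromatic ring with 2 hetero atoms, one six-membered aromatic ring of carbon only) in place of a group of 6 heavy atoms (3 carbon, 1 nitrogen, 1 oxygen, 1 sulfur; one five-membered non-aromatic ring with 2 hetero atoms), on an amine nitrogen in a ring. For the measured compounds named here, no measured pair isolates this exchange. Going by the values given here, the one measured step, from compound 2 to compound 3, concerns a different place and is within the scatter, so it does not inform this change. What does bear on it is compound 1, which carries the same entering group, though with a 4-methoxyphenyl rather than a 4-chlorophenyl, and gives the lowest number of the three. On that basis a drop in this assay is expected for compound 4, with a 2.0-fold lower number from compound 2 to compound 4 (0.29 log units; within the scatter) as the estimated size. The expected value for compound 4 is 4500 nM, in a range from 1800 nM to 11000 nM.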

Compound 4, half-maximal inhibitory concentration: 9940 nM
Compound 4: the middle estimate sits 2.2-fold (0.34 log units) below what was measured, and the stated range covers the measured number.
By their numbers in this assay, from the lowest: compound 1; then compounds 2, 4 and 3 (each within the scatter of the next).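

In this assay, putting the larger group with its added benzene ring in place of the smaller carbonyl-bearing ring, on an amine nitrogen in a ring, gives a 1.1-fold higher number from compound 2 to compound 4 (0.05 log units; within the scatter) and so leaves the two compounds indistinguishable: with a 4-chlorophenyl group in the molecule, this position accepts either group without a readable difference. A difference appears elsewhere in the molecule, where the entering group stays the same and chloro in place of methoxy on an aromatic carbon gives a 3.0-fold higher number from compound 1 to compound 4 (0.48 log units; beyond the scatter), a modest step but one beyond the scatter, so the entering group alone does not bring the lower number seen with compound 1. Nothing measured alongside these results explains either observation.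

For the compounds shown here, it remains open whether methoxy in place of chloro would give a similar step with the smaller ring on the nitrogen, as only one pair speaks to that exchange. The compounds shown also leave open how an ethoxy or dimethylamino group would behave in place of the chloro, and how an open chain such as an acetyl group would behave on that ring nitrogen.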